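Benzyloxy aryl substitution in a constrained glutamate scaffold

The source may hold more compounds than are shown below. What is called first, only, known or untested is meant among the compounds shown, and "the series" means these compounds.

Measured so far in an assay on CHO cells for binding affinity to metabotropic glutamate receptor 2 (Rattus norvegicus); a higher number here means a weaker inhibitor, a lower number a stronger inhibitor: compound 1 `N[C@]1(C(=O)O)[C@H]2[C@@H](C[C@H]1OCc1cccc(Cl)c1)[C@]2(F)C(=O)O` at 3.28 nM; compound 2 `N[C@]1(C(=O)O)[C@H]2[C@@H](C[C@H]1OCc1ccc(F)c(F)c1)[C@]2(F)C(=O)O` at 2.27 nM.

For the measured compounds named here, compound 2 holds the lowest of the two numbers in this assay, with compound 1 nearest, and the only measured step, a 1.4-fold lower number from compound 1 to compound 2 (0.16 log units; within the scatter), lies within the scatter. Compound 3 `N[C@]1(C(=O)O)[C@H]2[C@@H](C[C@H]1OCc1cc(F)ccc1F)[C@]2(F)C(=O)O` carries the change (2,5-difluorophenyl in place of 3,4-difluorophenyl on a saturated chain carbon bound to an oxygen on a saturated carbon). One aryl exchange on this position gave no step beyond the scatter, so no step beyond the scatter is expected for compound 3 either. Compound 3 is therefore estimated at 3 nM (range 1.2 nM to 8 nM), a step of a 1.3-fold higher number from compound 2 to compound 3 (0.12 log units; within the scatter) that is expected to stay within the scatter.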

Compound 3, inhibition constant: 14.4 nM
Beside the measured number, compound 3's estimate is 4.8-fold (0.68 log units) below it; the measured number lies above the stated range.
By their numbers in this assay, from the lowest: compounds 2 and 1 (each within the scatter of the next); then compound 3.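

The aryl group at this position is not freely interchangeable: in this assay, moving from 3,4-difluorophenyl to 2,5-difluorophenyl, with the same atoms joined differently, gives a 6.3-fold higher number from compound 2 to compound 3 (0.80 log units; beyond the scatter). The exchange from 3-chlorophenyl gives a 4.4-fold higher number from compound 1 to compound 3 (0.64 log units; beyond the scatter), so compound 3 stands apart from both earlier compounds, which remain within the scatter of each other. Nothing available here accounts for this difference. Still open, from the compounds shown here alone, is how a pyridine ring, or a methoxy group in place of the halogens, would read at this position.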